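Shortening a Long Chain on a Shared Nucleoside Core

This account rests on a few compounds, and the source may have more. Where it says the series, first, only, none or still open, it means among the compounds named here.

Compound 1 `CCCCCCCCCCCCCCCCNc1nc(=O)c2ncn([C@@H]3O[C@H](CO)[C@@H](O)[C@H]3O)c2c(=O)[nH]1` carries a long saturated chain on a nitrogen of its core. In an assay on isolated protein for inhibition of ATP-dependent RNA helicase SUPV3L1, mitochondrial (Homo sapiens) (a higher number here means a weaker inhibitor, a lower number a stronger inhibitor), compound 1 reaches only the limit of the assay, > 500 ug/mL, so no number is known for it (the limit of > 500 ug/mL in this assay, at which 1 of the 2 values shown sits). Compound 2 `CCCCCCCCCCCCNc1nc(=O)c2c(ncn2[C@@H]2C[C@H](O)[C@@H](CO)O2)c(=O)[nH]1`, with a shorter chain and a different sugar, gives in this assay 250 ug/mL. Compound 3 `CCCCCCCCCCCCCCNc1nc(=O)c2ncn([C@@H]3O[C@H](CO)[C@@H](O)[C@H]3O)c2c(=O)[nH]1` differs from compound 1 only by hydrogen in place of ethyl on a saturated chain carbon, ten or more bonds along the chain from a nitrogen on an aromatic ring. Within the data shown here, no measured pair isolates this change, so a shift no larger than the usual scatter is expected, an at least 1.2-fold lower number from compound 1 to compound 3 (0.09 log units; that floor lies within the scatter). Compound 3 is estimated at about 400 ug/mL, between 150 ug/mL and 1000 ug/mL.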

Compound 3, half-maximal inhibitory concentration: 300 ug/mL
For compound 3 the middle estimate is 1.3-fold (0.12 log units) above the measured one; measured number inside the range.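

Hydrogen in place of ethyl on a saturated chain carbon gives the first readable step at this position in this assay: an at least 1.6-fold lower number from compound 1 to compound 3 (0.22 log units; that floor lies within the scatter). From the compounds shown here alone, because compound 1 stands at a limit, the step has only a floor and its true size stays unknown: the limit of > 500 ug/mL in this assay, at which 1 of the 3 values shown sits. Compound 3 does show that this core with the shorter chain yields a real number. Going by these compounds, how an octyl chain, or an amine or a carboxylic acid on the chain, would read stays open. Compound 2 differs from compound 3 in both chain and sugar, so it cannot settle this.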